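Adding a further methoxy: compound 2 to compound 3

A few compounds are considered here, and "the series" means these few. Any claim that something is new, unique, unknown or untested is made for them only; others in the source may bear on it.

Working from an ADME assay on BJ cells (Homo sapiens) for cytotoxicity, read by MTT assay, with a stated time of 72 h (a lower number here means a stronger inhibitor, a higher number a weaker inhibitor), the series has two measured members on a shared core. Compound 1 `COc1ccc(CNc2ncnc3c2ncn3C2CCCO2)cc1` gives > 100000 nM, which is a limit of the assay and not a number. Compound 2 `COc1ccc(CNc2ncnc3c2ncn3C2CCCO2)cc1OC` gives > 100000 nM, again a limit and not a number, so its standing in this assay is known only as a bound.

Compound 3 `COc1cc(OC)c(OC)cc1CNc1ncnc2c1ncn2C1CCCO1` carries one further change: methoxy in place of hydrogen on an aromatic carbon. Among the measured compounds shown here, the new group is a methoxy in place of hydrogen on an aromatic carbon, the same kind of exchange as the only measured step, a step that the two limits leave unreadable from compound 1 to compound 2. That step has no readable size, so it gives no measure of what a further methoxy does. All that the series offers is the limit of > 100000 nM in this assay, at which 2 of the 2 values shown sit.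

No step beyond the usual scatter is expected in this assay, and no direction can be argued from these data. The estimated change is a step that the limit leaves unreadable from compound 2 to compound 3. Another report of a limit is the likeliest outcome. For compound 3 the expected value is 120000 nM, with an estimated range from 60000 nM to 250000 nM.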

Compound 3, half-maximal inhibitory concentration: > 100000 nM
Compound 3 was reported as a limit; the forecaster's own chance of this, stated with the estimate: 85%; the middle value is on the limit's open side.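

In this assay compound 3 gives > 100000 nM, a limit of the assay and not a number, so the methoxy exchange between compound 2 and compound 3 yields no readable step. The compounds shown leave open how far any of them lies from that limit, and whether the added methoxy groups change the value at all: the limit of > 100000 nM in this assay, at which 3 of the 3 values shown sit.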